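This account rests on a few compounds, and the source may have more. Where it says the series, first, only, none or still open, it means among the compounds named here.

Measured compounds:
compound 1 `CN(CCC#N)C[C@H]1CN(c2ccc(-n3cc(-c4ccccn4)cn3)c(F)c2)C(=O)O1` — a physicochemical assay for solubility, read by HPLC, with a stated time of 24 h (on this read-out lower numbers stand for lower solubility and higher numbers for higher solubility), 64500 nM
compound 2 `NC(=O)[C@H]1CN(c2ccc(-n3cc(-c4ccccn4)cn3)c(F)c2)C(=O)O1` — this assay 27200 nM

Compound 2 gives the lowest of the two numbers; its nearest neighbour is compound 1, and the step of a 2.4-fold lower number from compound 1 to compound 2 (0.37 log units; beyond the scatter) was modest. Compound 3 `CNC(=O)[C@H]1CN(c2ccc(-n3cc(-c4ccccn4)cn3)c(F)c2)C(=O)O1` is the unmeasured compound; it differs from compound 2 by methyl in place of hydrogen on an amide-type nitrogen. Among the measured compounds shown here, no measured step changes this amide nitrogen, so the only reference is the modest step from compound 1 to compound 2, which altered a different part of the same ring substituent. Compound 3 is therefore expected to show a step of a 1.1-fold lower number from compound 2 to compound 3 (0.04 log units; within the scatter), essentially none beyond the scatter, giving an estimate of 25000 nM (range 10000 nM to 60000 nM).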

Compound 3, solubility: 26200 nM
Compound 3: the middle estimate sits 1.0-fold (0.02 log units) below what was measured; low and high end bracket the measured number.
By their numbers in this assay, from the lowest: compounds 3 and 2 (each within the scatter of the next); then compound 1.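

In this assay, methyl in place of the amide hydrogen gives a 1.0-fold lower number from compound 2 to compound 3 (0.02 log units; within the scatter) and so leaves carbamoyl and methylcarbamoyl indistinguishable on this read-out. Methylcarbamoyl in place of ((2-cyanoethyl)(methyl)amino)methyl gives a 2.5-fold lower number from compound 1 to compound 3 (0.39 log units; beyond the scatter) and so the gap seen with carbamoyl remains with this methyl added. Nothing available here offers a reason for either step.

Going by these compounds, whether an ethyl or a second methyl on this nitrogen would also leave the number unchanged stays open. So does the result of a carboxylic acid in place of the amide.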